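A few compounds are considered here, and "the series" means these few. Any claim that something is new, unique, unknown or untested is made for them only; others in the source may bear on it.

Compound 1, `S=C(Nc1ccccc1)N1N=C(c2ccc(Cl)cc2)CC1c1ccc2c(c1)OCCO2`, in a functional assay on HCT-116 cells (Homo sapiens) for antiproliferative activity, read by MTT assay, with a stated time of 48 h (on this read-out higher numbers stand for weaker inhibition of growth and lower numbers for stronger inhibition of growth), gives > 200000 nM, which is a limit of the assay and not a number.
Compound 2, `CSc1ccc(C2=NN(C(=S)Nc3ccccc3)C(c3ccc4c(c3)OCCO4)C2)cc1`, in this assay gives 193000 nM.
Compound 3, `O=[N+]([O-])c1ccc(C2=NN(C(=S)Nc3ccccc3)C(c3ccc4c(c3)OCCO4)C2)cc1`, in this assay gives > 200000 nM, again a limit of the assay and not a number.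

Compound 3 thus stands at the edge of what this assay can report: the limit of > 200000 nM in this assay, at which 2 of the 3 values shown sit. The two measured steps that lead into compound 3 say little about its place. The step that the two limits leave unreadable from compound 1 to compound 3 cannot be read, as both ends are limits. The step of an at least 1.0-fold higher number from compound 2 to compound 3 (0.01 log units; that floor lies within the scatter) is only a floor that lies within the scatter of repeated measurements.

Compound 4, `S=C(Nc1ccccc1)N1N=C(c2ccc(Cl)c(Cl)c2)CC1c1ccc2c(c1)OCCO2`, differs from compound 3 in one place: 3,4-dichlorophenyl in place of 4-nitrophenyl on a carbon with a double bond to nitrogen. Compound 1, which carries a single chloro on that same ring, sits at the limit, and nothing in the measured steps separates any of the three compounds from one another beyond the scatter. Compound 4 is therefore expected to show a step of a number no higher from compound 3 to compound 4 (the limit leaves the size open) in this assay, that is, no change beyond the scatter. Compound 4 is estimated at 200000 nM in this assay, within a range from 100000 nM to 400000 nM, and it is likely that the assay will again report only a limit.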

Compound 4, concentration for 50% growth inhibition: 125000 nM
The estimate for compound 4 lay 1.6-fold (0.20 log units) above the measured number, and the stated range covers the measured number.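

Among the compounds shown here, the second chloro of the 3,4-dichlorophenyl group gives the series a second true number at this position, and that number allows the first step here with measured values at both ends: in this assay this is a 1.5-fold lower number from compound 2 to compound 4 (0.19 log units; within the scatter). Against the single chloro the change reads as an at least 1.6-fold lower number from compound 1 to compound 4 (0.20 log units; that floor lies within the scatter), and against the 4-nitrophenyl group it reads as an at least 1.6-fold lower number from compound 3 to compound 4 (0.20 log units; that floor lies within the scatter), so both of these are floors and do not give the full size of the change. No step at this carbon with a double bond to nitrogen is yet shown beyond the scatter, and compound 1 and compound 3 remain at a limit of the assay and not at a number: the limit of > 200000 nM in this assay, at which 2 of the 4 values shown sit.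

The compounds shown leave open whether an amine or a carboxylic acid on this phenyl ring, or a longer chain in its place, would move the number beyond the scatter. They also leave open whether a change away from this carbon, such as an amine on the 2,3-dihydro-1,4-benzodioxin-6-yl group, would do so.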